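Nitrile chain shortening: compound 3 to compound 4

The source may report more compounds than this note shows. Statements on the series, on what has been measured and on what is new or still open speak of the compounds shown alone.

The series keeps one core and varies only the substituent on the saturated chain carbon bound to an aromatic nitrogen. In an assay on isolated protein for displacement of a labelled ligand from growth hormone secretagogue receptor type 1 (Homo sapiens), with a stated time of 1 h (on this read-out higher numbers stand for weaker inhibition and lower numbers for stronger inhibition), compound 2 `CC(C)(N)C(=O)N[C@H](COCc1ccccc1)c1nnnn1CCCc1ccccc1` gives 200 nM. Compound 3 `CC(C)(N)C(=O)N[C@H](COCc1ccccc1)c1nnnn1CCCCC#N` gives 3120 nM in this assay, the higher of the two numbers shown; the separation is a 16-fold higher number from compound 2 to compound 3 (1.19 log units; beyond the scatter). Compound 1 `CC(C)(N)C(=O)N[C@H](COCc1ccccc1)c1nnnn1Cc1ccc(NS(C)(=O)=O)cc1` gives only a limit of this assay, > 5000 nM. The steps of an at least 25-fold lower number from compound 1 to compound 2 (1.39 log units; beyond the scatter) and an at least 1.6-fold lower number from compound 1 to compound 3 (0.20 log units; that floor lies within the scatter) therefore start from that limit, with the limit of > 5000 nM in this assay, at which 1 of the 3 values shown sits, as the reference point.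

Compound 4 `CC(C)(N)C(=O)N[C@H](COCc1ccccc1)c1nnnn1CC#N` differs from compound 3 by cyano in place of 3-cyanopropyl on a saturated chain carbon bound to an aromatic nitrogen. For the measured compounds named here, no measured step cuts the chain in this way; the only step touching the nitrile-bearing chain, a 16-fold higher number from compound 2 to compound 3 (1.19 log units; beyond the scatter), exchanged the terminal group and was large, while the chain itself was kept. Removing the chain removes the spacing that compound 2 and compound 3 share, so a number no lower than that of compound 3, and probably higher, is expected, with a real chance that only a limit is returned. The estimated step is a 1.6-fold higher number from compound 3 to compound 4 (0.20 log units; within the scatter). For compound 4 the expected value in this assay is 5000 nM, within a range from 1500 nM to 15000 nM.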

Compound 4, inhibition constant: 4170 nM
Compound 4: the middle estimate sits 1.2-fold (0.08 log units) above what was measured, and the stated range covers the measured number.
By their numbers in this assay, from the lowest: compound 2; then compounds 3 and 4 (each within the scatter of the next). At a limit, above all of these: compound 1.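

Cyano in place of 3-cyanopropyl on a saturated chain carbon bound to an aromatic nitrogen gives a 1.3-fold higher number from compound 3 to compound 4 (0.13 log units; within the scatter) in this assay, so between these two nitrile compounds the length of the chain carries no visible weight. Set against compound 2, the short nitrile sits as far off as the longer one, with a 21-fold higher number from compound 2 to compound 4 (1.32 log units; beyond the scatter) alongside a 16-fold higher number from compound 2 to compound 3 (1.19 log units; beyond the scatter), which leaves the phenyl-ended chain of compound 2 as the only substituent here with a number clearly lower than the others. Compound 1 gives only a limit. The step of an at least 1.1-fold lower number from compound 1 to compound 4 (0.07 log units; that floor lies within the scatter) therefore starts from that limit and cannot be read as a size: the limit of > 5000 nM in this assay, at which 1 of the 4 values shown sits.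

Whether the phenyl of compound 2 depends on its spacing stays open, since the shown compounds hold neither plain benzyl nor a longer chain ending in phenyl. Also open, as far as these compounds go, is whether the flat response to chain length is particular to the nitrile, or would hold for an amine or a carboxylic acid at the end of the same chains.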